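Dropping the Fluoro Group from Compound 2

The source may hold more compounds than are shown below. What is called first, only, known or untested is meant among the compounds shown, and "the series" means these compounds.

Compound 1 `CC(=O)N1CC[C@H](n2c(Nc3ccccc3)nc3cnc(Nc4ccc(N5CCN(C)CC5)cc4)nc32)C1` and compound 2 `CN1CCN(c2ccc(Nc3ncc4nc(Nc5ccc(F)cc5)n([C@@H]5CCN(C(=O)OC(C)(C)C)C5)c4n3)cc2)CC1` share one core. In a functional assay on HCC827 cells (Homo sapiens) for antiproliferative activity, read by MTT assay, with a stated time of 72 h (a higher number here means a weaker inhibitor, a lower number a stronger inhibitor), compound 1 gives 260 nM. In this assay compound 2 gives 27 nM, the lower of the two numbers, and this gap from compound 1 lies beyond the usual scatter. Compound 3 `CN1CCN(c2ccc(Nc3ncc4nc(Nc5ccccc5)n([C@@H]5CCN(C(=O)OC(C)(C)C)C5)c4n3)cc2)CC1` differs from compound 2 in one place: hydrogen in place of fluoro on an aromatic carbon. Within the data shown here, no measured pair shows this change, so its effect is not known here. The change is expected to move the number little in this assay, in neither direction beyond the scatter: a 1.3-fold higher number from compound 2 to compound 3 (0.11 log units; within the scatter). Compound 3 is therefore estimated at 35 nM, with a range from 14 nM to 90 nM.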

Compound 3, half-maximal inhibitory concentration: 12 nM
Beside the measured number, compound 3's estimate is 2.9-fold (0.46 log units) above it; the measured number lies below the stated range.
By their numbers in this assay, from the lowest: compound 3; then compound 2; then compound 1.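

In this assay the fluoro group is not needed at this position: going from 4-fluorophenyl to phenyl gives a 2.3-fold lower number from compound 2 to compound 3 (0.35 log units; beyond the scatter) and the number improves. Compound 3 also forms a one-place pair with compound 1, where 1-(tert-butoxycarbonyl)pyrrolidin-3-yl in place of 1-acetylpyrrolidin-3-yl on the aromatic nitrogen gives a 22-fold lower number from compound 1 to compound 3 (1.34 log units; beyond the scatter) and is the larger of the two steps. Nothing measured here explains either step.
On these data alone, whether chloro, methoxy or an amine on that aromatic carbon would match hydrogen or fluoro stays open. So does whether the fluoro step would be the same alongside 1-acetylpyrrolidin-3-yl.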